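Compound 2 to compound 3 in the amide series

The compounds below may be only part of what the source reports. "The series", "measured", "known", "first", "only" and "open" are said of these compounds alone.

In a functional assay on ID8 cells (Mus musculus) for antiproliferative activity (a higher number here means a weaker inhibitor, a lower number a stronger inhibitor), compound 1 (`O=C(Nc1ccc(O)c2c(=O)cc(-c3ccccc3Cl)oc12)c1ccc(Cl)cc1`) gives 5500 nM and compound 2 (`COc1ccc(C(=O)Nc2ccc(O)c3c(=O)cc(-c4ccccc4Cl)oc23)cc1`) gives 5000 nM as its value. The two numbers lie within the scatter of each other, so compound 2 stands level with compound 1 and no order can be read between them.

The next structure is compound 3 (`C[C@@H](NC(=O)OC(C)(C)C)C(=O)Nc1ccc(O)c2c(=O)cc(-c3ccccc3Cl)oc12`), which keeps the shared core. The change from compound 2 is 1-((tert-butoxycarbonyl)amino)ethyl in place of 4-methoxyphenyl on a carbonyl carbon and amounts to 1-((tert-butoxycarbonyl)amino)ethyl in place of 4-methoxyphenyl on a carbonyl carbon.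

For the measured compounds named here, the only measured step is a 1.1-fold lower number from compound 1 to compound 2 (0.04 log units; within the scatter) with methoxy in place of chloro on an aromatic carbon. That step stayed within the scatter, but it only exchanged a substituent on the 4-methoxyphenyl group's ring, whereas this change removes the whole group. Going by the values given here, the data therefore hold no direct precedent, and the uncertainty is wide.

No shift beyond the scatter is expected, and the estimated step is a 1.3-fold higher number from compound 2 to compound 3 (0.11 log units; within the scatter) in this assay as a working figure. For compound 3 the expected value is 6500 nM with an estimated range from 2000 nM to 20000 nM in this series.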

Compound 3, half-maximal inhibitory concentration: 104000 nM
Compound 3: middle estimate off by 16-fold (1.20 log units), on the low side; the whole stated range lies below it.
By their numbers in this assay, from the lowest: compounds 2 and 1 (each within the scatter of the next); then compound 3.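

In this assay, the group on the carbonyl carbon whose other neighbour is the amide-type nitrogen clearly matters: placing 1-((tert-butoxycarbonyl)amino)ethyl there in place of 4-methoxyphenyl gives a 21-fold higher number from compound 2 to compound 3 (1.32 log units; beyond the scatter), and placing it there in place of 4-chlorophenyl gives a 19-fold higher number from compound 1 to compound 3 (1.28 log units; beyond the scatter). The earlier step, a 1.1-fold lower number from compound 1 to compound 2 (0.04 log units; within the scatter), only exchanged a substituent on the aromatic ring and stayed within the scatter, whereas replacing the whole aryl group with this ring-free group produces a large loss from either starting compound. No measurement available here bears on what lies behind this loss.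

This single change removes the aromatic ring and introduces the tert-butoxycarbonyl-protected amino group and a defined stereocentre together, so the compounds shown cannot assign the loss to any one of these features. A free amine in place of the protected amino group, a simple alkyl chain on the carbonyl carbon, or the opposite stereocentre would each help separate these features, while a pyridine ring would test how far the position tolerates a different aromatic group.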